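The source may report more compounds than this note shows. Statements on the series, on what has been measured and on what is new or still open speak of the compounds shown alone.

Compound 1 `COc1ccc(-c2cc(C(=O)Nc3ccc(Oc4ccnc5[nH]ccc45)cc3)ncn2)cc1` gives 9830 nM in a functional assay on PC-3 cells (Homo sapiens) for cytotoxicity, read by MTT assay, with a stated time of 72 h; on this read-out lower numbers stand for stronger inhibition and higher numbers for weaker inhibition. Among the measured compounds shown here, compound 2 `O=C(Nc1ccc(Oc2ccnc3[nH]ccc23)cc1)c1cc(-c2ccc(C(F)(F)F)cc2)ncn1` gives 2160 nM in this assay, the lower of the two numbers recorded so far; the single measured step, a 4.6-fold lower number from compound 1 to compound 2 (0.66 log units; beyond the scatter), separates them. Compound 3 `Cc1ccc(-c2cc(C(=O)Nc3ccc(Oc4ccnc5[nH]ccc45)cc3)ncn2)cc1` differs from compound 2 by methyl in place of trifluoromethyl on an aromatic carbon. For the measured compounds named here, only the step from compound 1 to compound 2 touches the same aromatic carbon, and it involved a different incoming group, so it bears on compound 3 only loosely. With methyl replacing trifluoromethyl, the step of a 2.1-fold higher number from compound 2 to compound 3 (0.32 log units; beyond the scatter) is expected to return part of the way toward the number of compound 1, since the trifluoromethyl group was the feature carrying the step of a 4.6-fold lower number from compound 1 to compound 2 (0.66 log units; beyond the scatter). Compound 3 is therefore estimated at 4500 nM in this assay, with a range of 1500 nM to 14000 nM.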

Compound 3, half-maximal inhibitory concentration: 9880 nM
The estimate for compound 3 lay 2.2-fold (0.34 log units) below the measured number; low and high end bracket the measured number.
By their numbers in this assay, from the lowest: compound 2; then compounds 1 and 3 (each within the scatter of the next).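

In this assay, replacing trifluoromethyl with methyl on this aromatic carbon gives a 4.6-fold higher number from compound 2 to compound 3 (0.66 log units; beyond the scatter), so the whole advantage seen with trifluoromethyl is lost rather than partly kept. Methyl and methoxy are not separated at this position, with a 1.0-fold higher number from compound 1 to compound 3 (0.00 log units; within the scatter), which leaves trifluoromethyl as the only one of the three groups that stands apart from the others here. No measurement is available to explain why this group differs from the other two.

Still open, going by these compounds, is whether a chlorine atom or a nitrile on this carbon would track with trifluoromethyl or with methyl and methoxy. An amine or a carboxylic acid at the same position would test whether any other substituent can lower the number further.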